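A Methoxyphenyl Amide Follows Two Benzyl Amides

The compounds below may be only part of what the source reports. "The series", "measured", "known", "first", "only" and "open" are said of these compounds alone.

Compound 3 `COc1ccc2c(=O)c(/C=C/C(=O)NCc3ccc(C)cc3)coc2c1` stands at the edge of what a functional assay on A549 cells (Homo sapiens) for inhibition, read by MTT assay, with a stated time of 48 h (on this read-out lower numbers stand for stronger inhibition and higher numbers for weaker inhibition), can report: in this assay compound 3 gives > 100000 nM, which is a limit rather than a number. Compound 2 `COc1ccc2c(=O)c(/C=C/C(=O)NCc3ccc(F)cc3)coc2c1` shares that position, as in this assay compound 2 gives > 100000 nM, also a limit. Compound 1 `COc1ccc2c(=O)c(/C=C/C(=O)Nc3ccccc3)coc2c1` is the only one of the three with a measured number, giving 51000 nM in this assay. The change to compound 4 `COc1cccc(NC(=O)/C=C/c2coc3cc(OC)ccc3c2=O)c1` is 3-methoxyphenyl in place of 4-methylbenzyl on an amide-type nitrogen. Within the data shown here, two measured steps bear on it: an at least 1.9-fold higher number from compound 1 to compound 2 (0.29 log units; that floor lies within the scatter) and an at least 1.9-fold higher number from compound 1 to compound 3 (0.29 log units; that floor lies within the scatter), both floors lying within the scatter, and both running from an aryl amide to a benzyl amide. The step to compound 4 runs the other way, from a benzyl amide back to an aryl amide, while between compound 2 and compound 3 the comparison is a step that the two limits leave unreadable from compound 2 to compound 3. Since both limits sit at the limit of > 100000 nM in this assay, at which 2 of the 3 values shown sit, the data allow only the expectation that compound 4 lands at or under that limit, somewhere near compound 1. Compound 4 is therefore expected to give about 55000 nM in this assay, between 20000 nM and 150000 nM, a step estimated as an at least 1.8-fold lower number from compound 3 to compound 4 (0.25 log units; that floor lies within the scatter).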

Compound 4, half-maximal inhibitory concentration: 12800 nM
Estimate against measurement, compound 4: 4.3-fold (0.63 log units) above; the whole stated range lies above it.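

Methoxy in place of hydrogen on the aryl amide gives a 4.0-fold lower number from compound 1 to compound 4 (0.60 log units; beyond the scatter) in this assay and is the first step in this set with a readable size beyond the scatter, so the group on the amide nitrogen can respond to a change on its aromatic ring, not only to the swap between aryl and benzyl. Against the two benzyl amides the result reads as an at least 7.8-fold lower number from compound 3 to compound 4 (0.89 log units; beyond the scatter) and as an at least 7.8-fold lower number from compound 2 to compound 4 (0.89 log units; beyond the scatter) with both floors beyond the scatter, which neither earlier floor reached. These two steps are floors and not sizes, because compound 2 and compound 3 each stand at a limit: the limit of > 100000 nM in this assay, at which 2 of the 4 values shown sit.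

From the compounds shown here alone, whether the gain belongs to methoxy itself remains open, as an amine or a carboxylic acid in its place would test that. Also open, going by these compounds, is how methoxy would read on the benzyl amides.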